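Dropping a Chloro Group: Expected Cytotoxicity of Compound 4

The source may report more compounds than this note shows. Statements on the series, on what has been measured and on what is new or still open speak of the compounds shown alone.

Three compounds share one core and differ only in the groups on one of its rings. Compound 1 `COc1ccc2c(=O)c(-c3ccc(Oc4ccc(OC(F)(F)F)cc4)cc3)c(C)[nH]c2c1` carries a methoxy group, compound 2 `Cc1[nH]c2ccc(Cl)cc2c(=O)c1-c1ccc(Oc2ccc(OC(F)(F)F)cc2)cc1` a chloro group, and compound 3 `COc1cc2[nH]c(C)c(-c3ccc(Oc4ccc(OC(F)(F)F)cc4)cc3)c(=O)c2cc1Cl` both. In an ADME assay on HepG2 cells (Homo sapiens) for cytotoxicity, read by resazurin assay, with a stated time of 24 h (a lower number here means a stronger inhibitor, a higher number a weaker inhibitor), compound 1 gives > 10000 nM, a limit of the measurement rather than a number. Compound 2 gives only a limit, > 10000 nM. Compound 3 gives only a limit, > 10000 nM. The cores of compound 2 and compound 3 differ by hydrogen in place of methoxy on an aromatic carbon. From compound 3 to compound 1 the change is hydrogen in place of chloro on an aromatic carbon, and the step is a step that the two limits leave unreadable from compound 3 to compound 1, because of the limit of > 10000 nM in this assay, at which 3 of the 3 values shown sit. Compound 4 `Cc1[nH]c2ccccc2c(=O)c1-c1ccc(Oc2ccc(OC(F)(F)F)cc2)cc1` makes the same kind of change from compound 2, (hydrogen in place of chloro on an aromatic carbon); the place in compound 3 is ortho to a methoxy group (2 heavy atoms), while in compound 2 it is not. The expected step from compound 2 to compound 4 is a step that the limit leaves unreadable from compound 2 to compound 4, because of the limit of > 10000 nM in this assay, at which 3 of the 3 values shown sit. Compound 4 is expected to give about 20000 nM, most likely again as a limit.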

Compound 4, half-maximal inhibitory concentration: > 10000 nM
Compound 4: a limit, no number; the forecaster's own chance of this, stated with the estimate: 85%; the middle value does not contradict the limit.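

Neither the step to compound 4 from compound 2 nor the one from compound 1 can be read, because every compound stops at the same limit: the limit of > 10000 nM in this assay, at which 4 of the 4 values shown sit.

As far as these compounds go, whether chloro, methoxy or hydrogen on the shared core changes the result in this assay stays open.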